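A methyl shift at the limit of the assay

This account rests on a few compounds, and the source may have more. Where it says the series, first, only, none or still open, it means among the compounds named here.

Compound 1 `Fc1cccc(-c2nc(Nc3ccccc3Cl)c3cc(F)ccc3n2)c1`: > 50000 nM (a limit)
Compound 2 `Cc1ccc(Nc2nc(-c3cccc(F)c3)nc3ccc(F)cc23)cc1`: > 50000 nM (a limit)
Compound 3 `Cc1cccc(Nc2nc(-c3cccc(F)c3)nc3ccc(F)cc23)c1`: not yet measured

Both measured compounds were tested in a functional assay on HT29-AK cells (Homo sapiens) for cytotoxicity, read by MTT assay, with a stated time of 48 h; on this read-out higher numbers stand for weaker inhibition and lower numbers for stronger inhibition. For compound 1, the entry of > 50000 nM is a limit and not a number. For compound 2, the entry of > 50000 nM is likewise a limit. Among the compounds with values here, compound 2 thus stands with the only other measured compound, as the limit of > 50000 nM in this assay, at which 2 of the 2 values shown sit, shows.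

The change now followed is 3-methylphenyl in place of 4-methylphenyl on a nitrogen on an aromatic ring. Within the data shown here, the one measured step, at this same place, is a step that the two limits leave unreadable from compound 1 to compound 2, so it offers no size to carry over. It does show that 4-methylphenyl and 2-chlorophenyl both leave the reading at the limit. No step beyond the scatter is therefore expected in this assay, and the assay will most likely report only a limit again. The expected step is a number no higher from compound 2 to compound 3 (the limit leaves the size open). For compound 3, the estimated value is 50000 nM, with an expected range from 20000 nM to 100000 nM.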

Compound 3, half-maximal inhibitory concentration: > 50000 nM
Compound 3 gave a limit, no number; the forecaster's own chance of this, stated with the estimate: 80%; the middle value lies on the limit itself.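

In this assay compound 3 gives > 50000 nM as a limit and not a number. The steps from compound 1 and compound 2 to compound 3 cannot be read, and all three compounds share one reading: the limit of > 50000 nM in this assay, at which 3 of the 3 values shown sit. The compounds shown leave open how far each lies from that limit, and whether the 4-methylphenyl, 3-methylphenyl and 2-chlorophenyl groups differ at all in this assay.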